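Sigma receptor series: benzoxazolone amines, aryl change

The source may hold more compounds than are shown below. What is called first, only, known or untested is meant among the compounds shown, and "the series" means these compounds.

Measured so far:
compound 1, `COc1ccccc1CN(C)CCCCn1c(=O)oc2ccccc21`: 594 nM
compound 2, `O=C(NCc1ccccc1)C1CCN(Cc2ccccc2)CC1`: 22.5 nM

Notes on the series. Two compounds have a number in an assay on membranes from liver for displacement of a labelled ligand from Sigma non-opioid intracellular receptor 1 (Rattus norvegicus), read by scintillation counting; a lower number here means a stronger inhibitor, a higher number a weaker inhibitor. Compound 1 gives 594 nM there, the highest of the two numbers. Compound 2 gives 22.5 nM in this assay, the lower of the two, and the gap between the two numbers lies beyond the usual scatter. Among the compounds with values here, the two compounds share no common core, so their gap is read only as what the two values show; no step between them is given.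

Compound 3, `Cc1ccc(CN(C)CCCCn2c(=O)oc3ccccc32)c(C)c1`, has not been measured in this assay. It is the same as compound 1 except for one change: 2,4-dimethylphenyl in place of 2-methoxyphenyl on a saturated chain carbon bound to an amine nitrogen. Within the data shown here, no step between measured compounds of this kind is known here, so the size of the step can only be guessed from compound 1 alone. The expectation is a small step from compound 1 to compound 3 in this assay, of a 1.5-fold lower number from compound 1 to compound 3 (0.17 log units; within the scatter), toward a somewhat lower number, not clearly beyond the scatter. Compound 3 is estimated at 400 nM in this assay, with a range from 120 nM to 1300 nM.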

Compound 3, inhibition constant: 239 nM
The estimate for compound 3 lay 1.7-fold (0.22 log units) above the measured number; the measured number falls inside the stated range.
By their numbers in this assay, from the lowest: compound 2; then compound 3; then compound 1.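

Within the data shown here, this is the only step read so far at the aryl group on a saturated chain carbon bound to an amine nitrogen. In this assay, 2,4-dimethylphenyl in place of 2-methoxyphenyl gives a 2.5-fold lower number from compound 1 to compound 3 (0.40 log units; beyond the scatter), a modest step but one beyond the usual scatter, so the number at this position does respond to the aryl group. The 2-methoxyphenyl group, with its 1 hydrogen-bond acceptor, is also not needed to hold this level of binding, since the entering group has 0 hydrogen-bond acceptors and the number falls rather than rises, though no measurement at hand says what lies behind the step.

The change removes methoxy and brings in two methyl groups at once, so the step cannot be divided among them; 2-methylphenyl and 4-methylphenyl would separate those contributions. On these data alone, it also remains open whether the same aryl preference holds with a longer chain to the core or with a secondary amine in place of the methyl-bearing nitrogen.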